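Replacing methylsulfonyl with nitro on compound 1

This account rests on a few compounds, and the source may have more. Where it says the series, first, only, none or still open, it means among the compounds named here.

Compound 1, `CS(=O)(=O)c1ccc(-c2csc(N3N=C(c4ccc(Cl)s4)CC3c3ccc(F)cc3)n2)cc1`: in a functional assay on A549 cells (Homo sapiens) for antiproliferative activity, read by XTT assay, with a stated time of 24 h (on this read-out higher numbers stand for weaker inhibition and lower numbers for stronger inhibition), compound 1 gives > 500 ug/mL, which is a limit of the assay.
Compound 2, `Cc1ccc(C2=NN(c3nc(-c4ccc(S(C)(=O)=O)cc4)cs3)C(c3ccc(F)cc3)C2)s1`: in this assay compound 2 gives > 500 ug/mL, again a limit.
Compound 3, `COc1ccc(-c2csc(N3N=C(c4ccc(C)s4)CC3c3ccc(F)cc3)n2)cc1`: in this assay compound 3 gives 184 ug/mL.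

Compound 1 thus sits at the limit, as does compound 2, and only compound 3 returns a number. The step that the two limits leave unreadable from compound 1 to compound 2 cannot be sized because of the limit of > 500 ug/mL in this assay, at which 2 of the 3 values shown sit. Among the measured compounds shown here, the step of an at least 2.7-fold lower number from compound 2 to compound 3 (0.43 log units; beyond the scatter) is the one measured change that removes the methylsulfonyl group, and it lowered the number at least modestly. Compound 4, `O=[N+]([O-])c1ccc(-c2csc(N3N=C(c4ccc(Cl)s4)CC3c3ccc(F)cc3)n2)cc1`, differs from compound 1 by nitro in place of methylsulfonyl on an aromatic carbon. The nitro group is not the methoxy group, so the step from compound 2 to compound 3 is only a loose guide, but it is the sole recorded replacement of methylsulfonyl and it pointed downward. Compound 4 is therefore expected to fall somewhat below the limit, with a step of an at least 1.6-fold lower number from compound 1 to compound 4 (0.22 log units; that floor lies within the scatter) that may stay close to the scatter. For compound 4 the estimate is 300 ug/mL, between 100 ug/mL and 500 ug/mL.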

Compound 4, half-maximal inhibitory concentration: > 500 ug/mL
Compound 4 ended at the assay's limit; the forecaster's own chance of this, stated with the estimate: 45%; at least 1.6-fold (0.22 log units) between middle value and limit.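

Among the compounds shown here, compound 1 and compound 4 both stand at a limit in this assay and not at a number, so no step between them can be read: (the limit of > 500 ug/mL in this assay, at which 3 of the 4 values shown sit).

The compounds shown leave open whether nitro in place of methylsulfonyl changes the read-out at all, and how far either compound lies beyond that limit.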